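The source may report more compounds than this note shows. Statements on the series, on what has been measured and on what is new or still open speak of the compounds shown alone.

In a functional assay on PC-3 cells (Homo sapiens) for cytotoxicity, read by sulforhodamine B assay, with a stated time of 48 h (a lower number here means a stronger inhibitor of growth, a higher number a weaker inhibitor of growth), compound 1, whose structure is `CC1=C(C(=O)Nc2ccc(Cl)c(Cl)c2)C(c2cccc(O)c2)NC(=S)N1`, gives 14100 nM. Compound 2, with the structure `CC1=C(C(=O)Nc2ccc(F)c(Cl)c2)C(c2cccc(O)c2)NC(=S)N1`, is made from compound 1 by one change, (fluoro in place of chloro on an aromatic carbon). In this assay compound 2 gives 25100 nM, and the step recorded is a 1.8-fold higher number from compound 1 to compound 2 (0.25 log units; within the scatter).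

Compound 3, with the structure `COc1cccc(C2NC(=S)NC(C)=C2C(=O)Nc2ccc(Cl)c(Cl)c2)c1`, differs from compound 1 in its core by methyl in place of hydrogen on an oxygen on an aromatic ring. In this assay compound 3 gives 14500 nM, and the step from the first core to the second is a 1.0-fold higher number from compound 1 to compound 3 (0.01 log units; within the scatter), so the two cores give numbers that cannot be told apart here.

Compound 4, with the structure `COc1cccc(C2NC(=S)NC(C)=C2C(=O)Nc2ccc(F)c(Cl)c2)c1`, has not yet been measured. It differs from compound 3 by fluoro in place of chloro on an aromatic carbon, which is the same change that turns compound 1 into compound 2, made on the core of compound 3 rather than the core of compound 1; the place of the change is described in the same words in both pairs.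

The expectation for compound 4 rests on one measured pair, in which the step from compound 1 to compound 2 was a 1.8-fold higher number from compound 1 to compound 2 (0.25 log units; within the scatter), a step that stayed within the scatter. Because a 1.0-fold higher number from compound 1 to compound 3 (0.01 log units; within the scatter) shows the two cores behaving alike, the step from compound 3 to compound 4 is expected to be of similar size, estimated as a 1.5-fold higher number from compound 3 to compound 4 (0.18 log units; within the scatter). Compound 4 is therefore estimated to give 22000 nM in this assay, with a likely range from 9000 nM to 50000 nM.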

Compound 4, concentration for 50% growth inhibition: 23400 nM
For compound 4 the middle estimate is 1.1-fold (0.03 log units) below the measured one; low and high end bracket the measured number.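

In this assay, putting fluoro in place of chloro on the core of compound 3 gives a 1.6-fold higher number from compound 3 to compound 4 (0.21 log units; within the scatter) and this step cannot be told apart from the one seen on the core of compound 1: the same change on two cores in this assay, a 1.8-fold higher number (0.25 log units; within the scatter) from compound 1 to compound 2 and a 1.6-fold higher number (0.21 log units; within the scatter) from compound 3 to compound 4, 1.1-fold (0.04 log units) apart, within the scatter of two such steps

The methyl on the oxygen, read on the fluoro pair, gives a 1.1-fold lower number from compound 2 to compound 4 (0.03 log units; within the scatter) and this step likewise matches its counterpart on the chloro pair: the same change on two cores in this assay, a 1.0-fold higher number (0.01 log units; within the scatter) from compound 1 to compound 3 and a 1.1-fold lower number (0.03 log units; within the scatter) from compound 2 to compound 4, 1.1-fold (0.04 log units) apart, within the scatter of two such steps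

Across these four compounds, then, the fluoro for chloro exchange carries from one core to the other with no sign that the core matters, but each step lies within the scatter, and the two cores differ only by that one methyl, so this shows neither that the exchange itself has a real effect on growth inhibition nor that it would carry to a core that differs more widely.

The compounds shown leave open whether the same agreement would hold if an amine or a carboxylic acid stood in place of the halogen on the 3-chloro-4-fluorophenyl ring, or if a longer chain such as ethyl stood on the oxygen in place of methyl. They also leave open whether a step large enough to stand clear of the scatter would carry between cores in the same way.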